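Hydroxymethyl in place of bromo in the aryl hydrazide series

A few compounds are considered here, and "the series" means these few. Any claim that something is new, unique, unknown or untested is made for them only; others in the source may bear on it.

The series is a shared core carrying one group on the aryl ring, tested in an assay on isolated protein for inhibition of Polyunsaturated fatty acid 5-lipoxygenase (Homo sapiens); a lower number here means a stronger inhibitor, a higher number a weaker inhibitor. Compound 1 `Cc1cccc(N2CCCC(=O)N2)c1` gives 3400 nM, compound 2 `O=C1CCCN(c2cccc(Cl)c2)N1` gives 2500 nM, and compound 3 `O=C1CCCN(c2cccc(Br)c2)N1` gives 1800 nM. Compound 3 stands within the scatter of both neighbours: a 1.9-fold lower number from compound 1 to compound 3 (0.28 log units; within the scatter) and a 1.4-fold lower number from compound 2 to compound 3 (0.14 log units; within the scatter); likewise a 1.4-fold lower number from compound 1 to compound 2 (0.13 log units; within the scatter). None of the three groups tried so far sets itself apart in this assay.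

Compound 4 `O=C1CCCN(c2cccc(CO)c2)N1` is not yet measured. It differs from compound 3 by hydroxymethyl in place of bromo on an aromatic carbon. The three measured steps all exchange one small group for another at this carbon and all stay within the scatter, so the position tolerates methyl, chloro and bromo alike. For the measured compounds named here, no measured step introduces a hydrogen-bond donor or acceptor there, so the change to compound 4 has no direct precedent in this set.

The working expectation for compound 4 is therefore a number close to that of compound 3, with a wide range to cover the untested group: compound 4 is estimated at 3500 nM (range 1200 nM to 12000 nM). This expectation corresponds to a step of a 1.9-fold higher number from compound 3 to compound 4 (0.29 log units; within the scatter), which is not expected to exceed the scatter.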

Compound 4, half-maximal inhibitory concentration: 53000 nM
Beside the measured number, compound 4's estimate is 15-fold (1.18 log units) below it; the whole stated range lies below it.
By their numbers in this assay, from the lowest: compounds 3, 2 and 1 (each within the scatter of the next); then compound 4.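

In this assay, the aromatic carbon that took methyl, chloro and bromo within the scatter does not take hydroxymethyl in the same way: the step is a 29-fold higher number from compound 3 to compound 4 (1.47 log units; beyond the scatter) against bromo and a 21-fold higher number from compound 2 to compound 4 (1.33 log units; beyond the scatter) against chloro. For the compounds shown here, the closest comparison is with compound 1, where hydroxy in place of hydrogen on the saturated chain carbon is the only change, and even this gives a 16-fold higher number from compound 1 to compound 4 (1.19 log units; beyond the scatter) as a large step, so tolerance at this carbon does not extend to every small group and compound 4 alone breaks the pattern of the other three. Going by these compounds alone, compound 4 is also the only one here whose group counts a hydrogen-bond donor and acceptor, but this is a coincidence of structure only, and nothing available bears on what lies behind the large steps.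

From the compounds shown here alone, whether the loss follows the hydroxy hydrogen or the oxygen remains open, and methoxymethyl, aminomethyl or a carboxylic acid on this carbon would help separate the two. Also open, going by these compounds, is whether a longer chain such as hydroxyethyl behaves like hydroxymethyl.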